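A few compounds are considered here, and "the series" means these few. Any claim that something is new, unique, unknown or untested is made for them only; others in the source may bear on it.

Measured compounds:

compound 1, `COc1cc2c(Oc3ccc(NC(=O)c4nn(-c5ccccc5C(F)(F)F)c(=O)cc4C)cc3F)ccnc2cc1OCCCN1CCC(C)CC1`, in a functional assay on A549 cells (Homo sapiens) for inhibition, read by MTT assay, with a stated time of 72 h (a lower number here means a stronger inhibitor, a higher number a weaker inhibitor), gives 160 nM.
compound 2, `COc1cc2c(Oc3ccc(NC(=O)c4nn(-c5ccccc5C(F)(F)F)c(=O)cc4C)cc3F)ccnc2cc1OCCCN1CCN(C)CC1`, in this assay gives 170 nM.
compound 3, `COc1cc2c(Oc3ccc(NC(=O)c4nn(-c5ccc(Cl)cc5)c(=O)cc4C)cc3F)ccnc2cc1OCCCN1CCC(C)CC1`, in this assay gives 210 nM.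

The three sit close together. Within the core of compound 1, the change 4-methylpiperazin-1-yl in place of 4-methylpiperidin-1-yl on a saturated chain carbon, three bonds along the chain from an oxygen on an aromatic ring produced a 1.1-fold higher number from compound 1 to compound 2 (0.03 log units; within the scatter). The core of compound 3 differs from that of compound 1 by 4-chlorophenyl in place of 2-(trifluoromethyl)phenyl on an aromatic nitrogen, a difference that went with a 1.3-fold higher number from compound 1 to compound 3 (0.12 log units; within the scatter). Compound 2 and compound 3 are not linked by a measured step; their two values lie within the scatter of each other.

Compound 4, `COc1cc2c(Oc3ccc(NC(=O)c4nn(-c5ccc(Cl)cc5)c(=O)cc4C)cc3F)ccnc2cc1OCCCN1CCN(C)CC1`, is not yet measured. Among the compounds with values here, it carries the same change as the one from compound 1 to compound 2, now made on the core of compound 3: 4-methylpiperazin-1-yl in place of 4-methylpiperidin-1-yl on a saturated chain carbon, three bonds along the chain from an oxygen on an aromatic ring. The place is described in the same words for both pairs. Since the step from compound 1 to compound 2 was within the scatter, a step of similar size is expected here, a 1.1-fold higher number from compound 3 to compound 4 (0.04 log units; within the scatter), resting on a 1.1-fold higher number from compound 1 to compound 2 (0.03 log units; within the scatter) and on the value of compound 3, 210 nM. Compound 4 is therefore estimated at 230 nM in this assay, with a range from 120 nM to 450 nM.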

Compound 4, half-maximal inhibitory concentration: 270 nM
For compound 4 the middle estimate is 1.2-fold (0.07 log units) below the measured one; low and high end bracket the measured number.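

The swap of 4-methylpiperazin-1-yl in place of 4-methylpiperidin-1-yl, on a saturated chain carbon, now reads a 1.3-fold higher number from compound 3 to compound 4 (0.11 log units; within the scatter) in this assay, and it carries over from the earlier core without a difference beyond the scatter: the same change on two cores in this assay, a 1.1-fold higher number (0.03 log units; within the scatter) from compound 1 to compound 2 and a 1.3-fold higher number (0.11 log units; within the scatter) from compound 3 to compound 4, 1.2-fold (0.08 log units) apart, within the scatter of two such steps. The second change, 4-chlorophenyl in place of 2-(trifluoromethyl)phenyl on an aromatic nitrogen, reads a 1.6-fold higher number from compound 2 to compound 4 (0.20 log units; within the scatter) and likewise agrees with its earlier step: the same change on two cores in this assay, a 1.3-fold higher number (0.12 log units; within the scatter) from compound 1 to compound 3 and a 1.6-fold higher number (0.20 log units; within the scatter) from compound 2 to compound 4, 1.2-fold (0.08 log units) apart, within the scatter of two such steps. Within the data shown here, both changes therefore transfer between these two cores, but every step is within the scatter, so this shows only that neither change moved the number measurably here, not that a step of real size would carry over in the same way, or that the agreement extends to other cores.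

Still open, going by these compounds, is whether a morpholin-4-yl group in place of either ring on the chain, or a shorter chain such as 2-(4-methylpiperazin-1-yl)ethyl, would give a step beyond the scatter. The same question stands for an unsubstituted phenyl on the aromatic nitrogen, and for any of these changes on other cell lines.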